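A few compounds are considered here, and "the series" means these few. Any claim that something is new, unique, unknown or untested is made for them only; others in the source may bear on it.

Compound 1 `COC(=O)/C(=C\c1ccc(OC(=O)c2ccccc2)cc1)Sc1ccnc2cc(Cl)ccc12`: 30200 nM
Compound 2 `COC(=O)/C(=C\c1ccc(OC(=O)c2cccc(OC)c2OC)cc1)Sc1ccnc2cc(Cl)ccc12`: 13000 nM

In a functional assay on HL-60 cells (Homo sapiens) for cytotoxicity, read by MTT assay, with a stated time of 24 h (a higher number here means a weaker inhibitor, a lower number a stronger inhibitor), compound 2 stands lowest of the two numbers; its only neighbour is compound 1, and the single step shown is a 2.3-fold lower number from compound 1 to compound 2 (0.37 log units; beyond the scatter). Compound 3 `COC(=O)/C(=C\c1ccc(OC(=O)c2cc(OC)cc(OC)c2OC)cc1)Sc1ccnc2cc(Cl)ccc12` carries one further change, (methoxy in place of hydrogen on an aromatic carbon). The step bearing on it is that from compound 1 to compound 2, where adding two methoxy groups gave a modest lowering. A third methoxy is therefore expected to give a smaller step in the same direction, perhaps not beyond the scatter, with compound 3 estimated at 9000 nM (range 3500 nM to 25000 nM), a step of a 1.4-fold lower number from compound 2 to compound 3 (0.16 log units; within the scatter).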

Compound 3, half-maximal inhibitory concentration: 10700 nM
Compound 3: the middle estimate sits 1.2-fold (0.08 log units) below what was measured; low and high end bracket the measured number.
By their numbers in this assay, from the lowest: compounds 3 and 2 (each within the scatter of the next); then compound 1.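

In this assay, methoxy in this place, para to one methoxy group and meta to the other, gives a step that stays within the scatter (a 1.2-fold lower number from compound 2 to compound 3 (0.08 log units; within the scatter)). The 2,3,5-trimethoxyphenyl group still stands clear of phenyl (a 2.8-fold lower number from compound 1 to compound 3 (0.45 log units; beyond the scatter)), so the third methoxy keeps the difference from phenyl without a readable addition to it. Nothing available explains this result. Whether a hydroxy group or an amine in this place would give a step beyond the scatter stays open, as does which methoxy group accounts for the difference from phenyl.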